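Ether chain swap from compound 2 to compound 4

This account rests on a few compounds, and the source may have more. Where it says the series, first, only, none or still open, it means among the compounds named here.

compound 1 `CC(=O)c1ccc(OCCCCC#N)cc1O`: 0%
compound 2 `C=CCc1cc(C(C)=O)c(O)cc1OCC#N`: 2%
compound 3 `CCc1cc(C(C)=O)c(O)cc1OCCCCCCC(C)(C)C#N`: 30%

In an assay on isolated protein for binding affinity to leukotriene B4 receptor 1 (Homo sapiens), tested at 1 uM (on this read-out lower numbers stand for less inhibition and higher numbers for more inhibition at the one concentration tested (going by the name of the read-out)), compound 2 gives 2%, the second highest of the three numbers; compound 1 sits within the scatter of it, while compound 3 lies beyond the scatter, higher. Compound 4 `C#CCCCCOc1cc(O)c(C(C)=O)cc1CC=C` differs from compound 2 by pent-4-yn-1-yl in place of cyano on a saturated chain carbon bound to an oxygen on an aromatic ring. Among the measured compounds shown here, no step between two measured compounds isolates this change; the only hint is that compound 3, carrying the longest chain of the three, returns the highest number in this assay. A modest upward step is expected, a number 13 percentage points higher from compound 2 to compound 4 (beyond the scatter), though it may not clear the scatter. Compound 4 is estimated at 15% in this assay, within 0% to 40%.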

Compound 4, a percentage reported as inhibition, at one concentration (the size of the read-out at that concentration, not a potency): 29%
Estimate against measurement, compound 4: 14 percentage points below; measured number inside the range.
By their numbers in this assay, from the lowest: compounds 1 and 2 (each within the scatter of the next); then compounds 4 and 3 (each within the scatter of the next).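

In this assay, among the compounds shown here, pent-4-yn-1-yl in place of cyano on a saturated chain carbon bound to an oxygen on an aromatic ring gives a number 27 percentage points higher from compound 2 to compound 4 (beyond the scatter) as the first step that changes one place only. The number at this position therefore responds to the group carried on the ether chain, with the rest of the core of compound 2 held fixed. No measurement bearing on the reason for this step is available.

Still open, going by these compounds, is whether the added chain length or the alkyne accounts for the step. A plain hexyl chain in place of hex-5-yn-1-yl, or a carboxylic acid in place of cyano, would test this on the same core.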